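This account rests on a few compounds, and the source may have more. Where it says the series, first, only, none or still open, it means among the compounds named here.

Measured in a physicochemical assay for solubility, in phosphate buffer, at pH 7.4; on this read-out lower numbers stand for lower solubility and higher numbers for higher solubility:

- Compound 1 `CCOC(=O)c1c(-c2cccc(F)c2)[nH]c2cc(OC)ccc2c1=O`: > 100000 nM (a limit)
- Compound 2 `CCOC(=O)c1c(-c2ccc(Cl)cc2)[nH]c2cccc(OC)c2c1=O`: > 100000 nM (a limit)
- Compound 3 `CCOC(=O)c1c(-c2ccc(C(C)(C)C)cc2)[nH]c2cccc(OC)c2c1=O`: 1000 nM

Compound 1 sits at the limit of > 100000 nM in this assay, at which 2 of the 3 values shown sit. That is a limit and not a number, so any step starting from compound 1 can only be judged roughly.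

Compound 4 `CCOC(=O)c1c(-c2cccc([N+](=O)[O-])c2)[nH]c2cc(OC)ccc2c1=O` keeps the core of compound 1 but carries nitro in place of fluoro on an aromatic carbon, turning 3-fluorophenyl into 3-nitrophenyl: nitro in place of fluoro on an aromatic carbon.

Going by the values given here, only one measured step exists, an at least 100-fold lower number from compound 2 to compound 3 (2.00 log units; beyond the scatter). It is large, but it swaps a different pair of groups on a different core, so it offers only a loose warning that one group exchange can move this assay a long way. It says nothing direct about nitro. A modest move to a lower number is therefore expected, or none beyond the scatter, and a second limit reading would be no surprise.

The expected size is an at least 2.0-fold lower number from compound 1 to compound 4 (0.30 log units; that floor lies within the scatter), and this is an estimate. For compound 4 the estimated value is 50000 nM, with an expected range of 8000 nM to 100000 nM.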

Compound 4, solubility: 13000 nM
Compound 4: middle estimate off by 3.8-fold (0.59 log units), on the high side; low and high end bracket the measured number.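

Turning 3-fluorophenyl into 3-nitrophenyl gives, in this assay, an at least 7.6-fold lower number from compound 1 to compound 4 (0.88 log units; beyond the scatter). This shows that the group at this place on the ring matters on this core, since a single exchange moves the read-out beyond the scatter, and compound 4, at 13000 nM, gives this core a real number rather than a limit. The step can be stated only as a floor because the value of compound 1 is a limit, not a number: the limit of > 100000 nM in this assay, at which 2 of the 4 values shown sit.

The true size of the step therefore stays unknown, and the compounds shown cannot tell which difference between fluoro and nitro drives it. On these data alone, it also remains open how an amine or a carboxylic acid in the same place would read, and whether the step would hold on a different core.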